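The source may report more compounds than this note shows. Statements on the series, on what has been measured and on what is new or still open speak of the compounds shown alone.

Of the compounds shown here, three sharing one core have been measured in a functional assay (aorta) for antagonist activity, with Oryctolagus cuniculus as the target; a lower number here means a stronger inhibitor, a higher number a weaker inhibitor. Compound 1 `CCCCc1ccc(CNC(=O)Nc2ccccc2)c(=O)n1Cc1ccc(-c2ccccc2-c2nn[nH]n2)cc1` gives 30 nM. Compound 2 `CCCCc1ccc(CNC(C)=O)c(=O)n1Cc1ccc(-c2ccccc2-c2nn[nH]n2)cc1` gives 3 nM, and compound 3 `CCCCc1ccc(CN(C)S(=O)(=O)c2ccccc2)c(=O)n1Cc1ccc(-c2ccccc2-c2nn[nH]n2)cc1` gives 2 nM. Compound 2 thus stands second highest of the three numbers; the nearer gap, a 1.5-fold lower number from compound 2 to compound 3 (0.18 log units; within the scatter), lies within the scatter, while the wider one, a 10-fold lower number from compound 1 to compound 2 (1.00 log units; beyond the scatter), lies beyond it. The next compound, compound 4 `CCCCc1ccc(C)c(=O)n1Cc1ccc(-c2ccccc2-c2nn[nH]n2)cc1`, differs from compound 2 in one place: hydrogen in place of acetamido on a saturated chain carbon bound to an aromatic carbon. The measured steps that touch this place are a 10-fold lower number from compound 1 to compound 2 (1.00 log units; beyond the scatter) and a 1.5-fold lower number from compound 2 to compound 3 (0.18 log units; within the scatter), so exchanging one group on that carbon for another has ranged from no change beyond the scatter to a modest one. Neither step removed the group altogether, so the data give no direct measure of that move, and the outcome is open in either direction. Compound 4 is therefore expected to give up some potency in this assay, with an estimated step of a 3.3-fold higher number from compound 2 to compound 4 (0.52 log units; beyond the scatter). The value estimated for compound 4 is 10 nM, in the range 2 nM to 60 nM.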

Compound 4, half-maximal inhibitory concentration: 7 nM
For compound 4 the middle estimate is 1.4-fold (0.15 log units) above the measured one, within the range that was stated.
By their numbers in this assay, from the lowest: compounds 3 and 2 (each within the scatter of the next); then compound 4; then compound 1.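

Removing the substituent altogether, the change from acetamidomethyl to methyl, gives the first direct measure of this move in this assay: the number rises when the acetamido group leaves, a 2.3-fold higher number from compound 2 to compound 4 (0.37 log units; beyond the scatter), and when the methyl(phenylsulfonyl)amino group leaves, a 3.5-fold higher number from compound 3 to compound 4 (0.54 log units; beyond the scatter), but falls when the (phenylcarbamoyl)amino group leaves, a 4.3-fold lower number from compound 1 to compound 4 (0.63 log units; beyond the scatter). The direction of the step on this saturated chain carbon therefore depends on which group is removed: compounds 2 and 3 fit the reading that a group here helps, while compound 1 goes against it. No measurement bears on why the steps differ in direction.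

The compounds shown leave open where a free amine, a hydroxyl or a carboxylic acid on this carbon would fall relative to compound 4. They also leave open whether a plain ethyl or longer alkyl chain, with no amide or sulfonamide in it, would match the acetamido group of compound 2 or give a number closer to that of compound 1.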